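Compound 3 to compound 4: ethoxy in place of bromo

The compounds below may be only part of what the source reports. "The series", "measured", "known", "first", "only" and "open" are said of these compounds alone.

In a functional assay on HeLa cells (Homo sapiens) for inhibition, read by sulforhodamine B assay (a higher number here means a weaker inhibitor, a lower number a stronger inhibitor), compound 1 `CCCc1ccc(NC2=CC(=O)c3nc4n(c3C2=O)[C@H]2OC[C@@H](O)[C@H]2OC4)cc1` gives 4990 nM and compound 3 `O=C1C=C(Nc2ccc(Br)cc2)C(=O)c2c1nc1n2[C@H]2OC[C@@H](O)[C@H]2OC1` gives 3830 nM as measured numbers. Bromo in place of propyl gives a 1.3-fold lower number from compound 1 to compound 3 (0.11 log units; within the scatter) and leaves compound 3 level with compound 1 on the numbers available. Compound 2 `O=C1C=C(NC2CCCC2)C(=O)c2c1nc1n2[C@H]2OC[C@@H](O)[C@H]2OC1` gives > 16000 nM in this assay and that value is a limit. On the amine nitrogen, cyclopentyl in place of 4-propylphenyl gives an at least 3.2-fold higher number from compound 1 to compound 2 (0.50 log units; beyond the scatter) while 4-bromophenyl in place of cyclopentyl gives an at least 4.1-fold lower number from compound 2 to compound 3 (0.62 log units; beyond the scatter) in the opposite direction.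

Compound 4 `CCOc1ccc(NC2=CC(=O)c3nc4n(c3C2=O)[C@H]2OC[C@@H](O)[C@H]2OC4)cc1` keeps the phenyl group and changes only its substituent: ethoxy in place of bromo on an aromatic carbon, para to a large group, counted as ethoxy in place of bromo on an aromatic carbon for this exchange. The steps through compound 2 replace the whole group on the nitrogen and bear on this change only weakly. The closer precedent is the exchange at the same place between compound 1 and compound 3. With a 1.3-fold lower number from compound 1 to compound 3 (0.11 log units; within the scatter) as that precedent, no step beyond the scatter is expected in this assay and no direction is favoured. The expected step is a 1.0-fold higher number from compound 3 to compound 4 (0.02 log units; within the scatter) on this estimate. For compound 4 the estimated value is 4000 nM with an expected range from 1800 nM to 9000 nM in this estimate.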

Compound 4, half-maximal inhibitory concentration: 3110 nM
Beside the measured number, compound 4's estimate is 1.3-fold (0.11 log units) above it, within the range that was stated.
By their numbers in this assay, from the lowest: compounds 4, 3 and 1 (each within the scatter of the next). At a limit, above all of these: compound 2.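

In this assay, ethoxy at this place, para to a large group, brings in an oxygen and the series' first hydrogen-bond acceptor on the phenyl substituent, yet the reading stays level with both earlier groups: a 1.2-fold lower number from compound 3 to compound 4 (0.09 log units; within the scatter), and a 1.6-fold lower number from compound 1 to compound 4 (0.21 log units; within the scatter). Among these compounds, the only new step beyond the scatter lies on the amine nitrogen, an at least 5.1-fold lower number from compound 2 to compound 4 (0.71 log units; beyond the scatter), and its size is only a bound, since the value of compound 2 is a limit: the limit of > 16000 nM in this assay, at which 1 of the 4 values shown sits. Compounds 1, 3 and 4 now give three substituents at this one place with no separation among them, while compound 2, with cyclopentyl on the nitrogen, is the only compound shown that stands apart from them.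

From the compounds shown here alone, it remains open whether any group at this place can move the number beyond the scatter, and a primary amine, a carboxylic acid or a longer chain such as hexyloxy would test the limits of this flat stretch. Also open, going by these compounds, is how far compound 2 truly lies from the phenyl compounds, and whether a group on another carbon of the phenyl ring would behave as these three do.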